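The source may report more compounds than this note shows. Statements on the series, on what has been measured and on what is new or still open speak of the compounds shown alone.

In an assay on isolated protein (spleen) for agonist activity at Alpha-1B adrenergic receptor (Rattus norvegicus) (a higher number here means that more compound is needed for the effect, a lower number that less compound is needed), compound 2 `CC(=O)Nc1cccc2c1CCCC2c1c[nH]cn1` gives 14500 nM, while compound 1 `CC(C)S(=O)(=O)Nc1cccc2c1CCCC2c1c[nH]cn1` gives 14100 nM; these two numbers sit within the scatter of each other, so on the measurements so far compound 2 is not set apart. Among the measured compounds shown here, the one step measured, a 1.0-fold higher number from compound 1 to compound 2 (0.01 log units; within the scatter), shows that acetyl in place of isopropylsulfonyl on a nitrogen on an aromatic ring left the number unchanged beyond the scatter. Compound 3 `Nc1cccc2c1CCCC2c1c[nH]cn1` has not been measured; it differs from compound 2 in that (hydrogen in place of acetyl on a nitrogen on an aromatic ring), so acetamido becomes amino. For the measured compounds named here, that earlier step bears on it only indirectly: swapping one group on this nitrogen for another made no difference, but removing the group altogether has no measured counterpart. The expectation is therefore a step in this assay of about a 1.0-fold lower number from compound 2 to compound 3 (0.02 log units; within the scatter), meaning no change beyond the scatter, with wide uncertainty. Compound 3 is thus estimated at 14000 nM, between 4500 nM and 45000 nM.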

Compound 3, half-maximal effective concentration: 977 nM
Estimate against measurement, compound 3: 14-fold (1.16 log units) above; the whole stated range lies above it.
By their numbers in this assay, from the lowest: compound 3; then compounds 1 and 2 (each within the scatter of the next).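

In this assay, what sits on this nitrogen does matter, although swapping acetyl for isopropylsulfonyl had suggested otherwise: removing either group gives a large step (a 15-fold lower number from compound 2 to compound 3 (1.17 log units; beyond the scatter); a 14-fold lower number from compound 1 to compound 3 (1.16 log units; beyond the scatter)). Compound 1 and compound 2 both carry a group on the nitrogen, so the difference between them could not show what happens when only hydrogen remains there. No measurement here explains why the number drops so far when the group is removed.

Still open, as far as these compounds go, is whether any group on this nitrogen raises the number or only groups of the size of acetyl and isopropylsulfonyl, which a single methyl there would help to separate. Also open, from the compounds shown here alone, is whether the nitrogen itself is needed, which a hydroxyl in place of the amino group would test.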